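This account rests on a few compounds, and the source may have more. Where it says the series, first, only, none or still open, it means among the compounds named here.

In a functional assay on FaDu cells (Homo sapiens) for cytotoxicity, read by MTT assay, with a stated time of 72 h (a higher number here means that more compound is tolerated, a lower number that less compound is tolerated), compound 1 (`COc1ccc(NC(=O)C(=O)c2cn(C(C)C)c3c(Cl)cccc23)cn1`) gives 10200 nM while compound 2 (`COc1ccc(NC(=O)C(=O)c2cn(C(C)C)c3ncccc23)cn1`) gives 126 nM and compound 3 (`CCn1cc(C(=O)C(=O)Nc2ccnc(OC)c2)c2ccccc21`) gives 4180 nM as its reading. Compound 3 therefore stands in the middle of the three. Its number is lower than that of compound 1 and higher than that of compound 2, and both gaps lie beyond the usual scatter, with the gap to compound 2 much the wider.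

Compound 4 (`CCn1cc(C(=O)C(=O)Nc2ccncc2)c2ccccc21`) differs from compound 3 in one place, with hydrogen in place of methoxy on an aromatic carbon next to the ring nitrogen (hydrogen in place of methoxy on an aromatic carbon). The 2-methoxypyridin-4-yl group thus becomes pyridin-4-yl.

Going by the values given here, no pair of measured compounds isolates this change, and all three measured compounds carry a methoxy group, so the data give no direct guide to its effect. A modest rise in the number is tentatively expected for the estimated step (a 1.4-fold higher number from compound 3 to compound 4 (0.16 log units; within the scatter)), which would mean that more compound is tolerated, although a step within the scatter would be no surprise. The span stays wide, as compound 2 at 126 nM and compound 1 at 10200 nM lie far apart. For compound 4 the estimated value is 6000 nM with an expected range from 1500 nM to 24000 nM in this measurement.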

Compound 4, concentration lethal to 50% of the cells: > 10000 nM
Compound 4 gave a limit, no number (the forecaster's own chance of this, stated with the estimate: 20%); middle value at least 1.6-fold (0.22 log units) away from the limit.
By their numbers in this assay, from the lowest: compound 2; then compound 3; then compound 1.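

Going by these compounds alone, the change from 2-methoxypyridin-4-yl to pyridin-4-yl gives the first one-place comparison in this set, and it shows that the group on this aromatic carbon next to the ring nitrogen affects the reading: replacing methoxy with hydrogen gives an at least 2.3-fold higher number from compound 3 to compound 4 (0.37 log units; beyond the scatter) in this assay. More compound is therefore tolerated without the methoxy group, so this position is not neutral on the core shared by these two compounds. The reading for compound 4 is a limit and not a number, so the step gives only the smallest size the change can have: the limit of > 10000 nM in this assay, at which 1 of the 4 values shown sits.

The compounds shown leave open how large the step really is, and whether methoxy is special at this position or whether a fluorine atom, an amine or a longer chain such as ethoxy on the same carbon would give a similar reading. They also leave open whether the same change would have a step of similar size on the core of compound 2, which has by far the lowest number of the set.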